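The compounds below may be only part of what the source reports. "The series", "measured", "known", "first", "only" and "open" are said of these compounds alone.

Going by the values given here, compound 3 `CN1CCN(c2ccc(Nc3nc(-c4cccc(NC(=O)c5ccccc5F)c4)sc3C(N)=O)cc2)CC1` is the only compound here with a number: in a functional assay on Raji cells (Homo sapiens) for antiproliferative activity, read by CCK-8 assay, with a stated time of 72 h (on this read-out lower numbers stand for stronger inhibition and higher numbers for weaker inhibition), compound 3 gives 3270 nM. Compound 1 `CCOC(=O)c1sc(-c2cccc(NC(=O)c3ccc(F)c(Cl)c3)c2)nc1Nc1ccc(N2CCN(C)CC2)cc1` belongs to the same series, and in this assay compound 1 gives "not determined" (no result reported). Compound 2 `CN1CCN(c2ccc(Nc3nc(-c4cccc(NC(=O)c5cccc(F)c5)c4)sc3C(N)=O)cc2)CC1` likewise belongs to the same series, and in this assay compound 2 gives "not determined" (no result reported). Among the compounds with values here, with no result reported for these two compounds, no comparison between measured compounds is available. Compound 4 `CN1CCN(c2ccc(Nc3nc(-c4cccc(NC(=O)c5ccc(F)c(Cl)c5)c4)sc3C(N)=O)cc2)CC1` differs from compound 3 by one change: 3-chloro-4-fluorophenyl in place of 2-fluorophenyl on a carbonyl carbon. Within the data shown here, with no measured step of this kind, no direction can be read from the data, and a step no larger than the usual scatter is expected from compound 3 to compound 4, amounting to a 1.3-fold lower number from compound 3 to compound 4 (0.12 log units; within the scatter). Compound 4 is accordingly estimated at 2500 nM, within a range from 700 nM to 9000 nM.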

Compound 4, half-maximal inhibitory concentration: 6230 nM
Compound 4: the middle estimate sits 2.5-fold (0.40 log units) below what was measured; low and high end bracket the measured number.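

Putting 3-chloro-4-fluorophenyl in place of 2-fluorophenyl on a carbonyl carbon gives, in this assay, a 1.9-fold higher number from compound 3 to compound 4 (0.28 log units; within the scatter). Going by these compounds alone, this is the first measured step at this position, and it shows that these two substituted phenyl groups cannot be told apart here, even though one carries an added chlorine. Nothing available explains this result.

The compounds shown leave open whether a phenyl ring carrying an amine or a carboxylic acid at this position would give a step beyond the scatter.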